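Freeing the Acid on a Second Core

The source may report more compounds than this note shows. Statements on the series, on what has been measured and on what is new or still open speak of the compounds shown alone.

Two of the three measured compounds share one core and differ only at a single spot. Compound 1, `COC(=O)c1cccc2c(C(=O)c3ccccc3)cc(C(=O)c3ccc(C(F)(F)F)cc3)c-2c1`, carries a methyl ester, while compound 2, `O=C(O)c1cccc2c(C(=O)c3ccccc3)cc(C(=O)c3ccc(C(F)(F)F)cc3)c-2c1`, carries the free acid. In an assay on cells for displacement of a labelled ligand from Orexin receptor type 2 (Homo sapiens), read by scintillation counting, with stated times of 10 min and 90 min, tested at 10 uM (on this read-out higher numbers stand for more inhibition at the one concentration tested (going by the name of the read-out) and lower numbers for less inhibition), compound 1 gives 27% and compound 2 gives 26.4%. The change between them is hydrogen in place of methyl on an oxygen next to a carbonyl group and it produced a number 0.6 percentage points lower from compound 1 to compound 2 (within the scatter), so the two results are indistinguishable.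

Compound 3, `COC(=O)Cc1ccc2ccc(C(=O)c3ccc(C(F)(F)F)cc3)c-2cc1`, is built on a different core, and how the two cores differ is not broken down here. In this assay compound 3 gives 1%, the lowest of the three numbers and well separated from both other compounds.

Compound 4, `O=C(O)Cc1ccc2ccc(C(=O)c3ccc(C(F)(F)F)cc3)c-2cc1`, is not yet measured. Its difference from compound 3 reads (hydrogen in place of methyl on an oxygen next to a carbonyl group). The spot where the change happens is described in exactly the same words as for the pair of compound 1 and compound 2, so this is the same change applied to the second core. Because the earlier pair showed a number 0.6 percentage points lower from compound 1 to compound 2 (within the scatter), the new step is expected to be a number 1 percentage points higher from compound 3 to compound 4 (within the scatter). Compound 4 is therefore expected to give about 2% in this assay. The estimate for compound 4 should lie between -8% and 12%.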

Compound 4, a percentage reported as inhibition, at one concentration (the size of the read-out at that concentration, not a potency): 11.2%
Beside the measured number, compound 4's estimate is 9.2 percentage points below it, within the range that was stated.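

Replacing the methyl of the ester with hydrogen, which turns (methoxycarbonyl)methyl into carboxymethyl, gave a number 10.2 percentage points higher from compound 3 to compound 4 (beyond the scatter) in this assay. For the compounds shown here, although only this step lies beyond the scatter, it cannot be firmly separated from the same change on the other core: the same change on two cores in this assay, a number 0.6 percentage points lower (within the scatter) from compound 1 to compound 2 and a number 10.2 percentage points higher (beyond the scatter) from compound 3 to compound 4, 10.8 percentage points apart, within the scatter of two such steps. The two pairs therefore give no firm sign that the core alters the effect of this change, but they do not prove that the effect carries over unchanged, as this is a comparison of just two cores, each tested at a single concentration that gives the size of inhibition rather than a potency.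

The compounds shown leave open how either core would respond if the ester or acid gave way to another group, such as an amide or an amine, or if a longer chain carried the acid. They also leave open whether the ester and acid on each core would compare in the same way at other concentrations, with a stronger or weaker effect than at the one concentration tested.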